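Replacing a Methyl Group by a Difluorophenyl: an Expectation

This account rests on a few compounds, and the source may have more. Where it says the series, first, only, none or still open, it means among the compounds named here.

Compound 1, `CC(C)(C)n1ncc(OCc2nnc(-c3ccc(Cl)cc3Cl)s2)c(Cl)c1=O`, in a functional assay on the whole organism for inhibition, with Mythimna separata as the target, with a stated time of 5 days (on this read-out lower numbers stand for an effect already at smaller amounts and higher numbers for an effect only at larger amounts of compound), gives 62200 nM.
Compound 2, `CC(C)(C)n1ncc(OCc2nnc(-c3ccc(Cl)cc3)s2)c(Cl)c1=O`, in this assay gives 106000 nM.
Compound 3, `Cc1nnc(COc2cnn(C(C)(C)C)c(=O)c2Cl)o1`, in this assay gives only a limit, > 299000 nM.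

Compound 3 stands at the limit of > 299000 nM in this assay, at which 1 of the 3 values shown sits. Between compound 1 and compound 2 the measured step is a 1.7-fold higher number from compound 1 to compound 2 (0.23 log units; within the scatter). Compound 4, `CC(C)(C)n1ncc(OCc2nnc(-c3c(F)cccc3F)o2)c(Cl)c1=O`, differs from compound 3 by 2,6-difluorophenyl in place of methyl on an aromatic carbon. Going by the values given here, no measured step covers the exchange of a methyl for an aryl group, so the two aryl-bearing compounds 1 and 2 give the only orientation: both deliver numbers rather than limits. On that basis compound 4 is expected to give a number near those of compounds 1 and 2, an estimate of 150000 nM with a range from 50000 nM to 450000 nM. This estimate means an expected step of an at least 1.9-fold lower number from compound 3 to compound 4 (0.29 log units; that floor lies within the scatter), with a real chance of a limit again.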

Compound 4, half-maximal effective concentration: 45400 nM
Compound 4: the middle estimate sits 3.3-fold (0.52 log units) above what was measured; measured number outside the range, below it.
By their numbers in this assay, from the lowest: compounds 4, 1 and 2 (each within the scatter of the next, the first and the last beyond it). At a limit, above all of these: compound 3.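

In this assay, 2,6-difluorophenyl in place of methyl on this aromatic carbon of the five-membered ring gives an at least 6.5-fold lower number from compound 3 to compound 4 (0.81 log units; beyond the scatter), the first step measured at this position. Compound 3 gives only a limit, so this step has a floor but no known full size: the limit of > 299000 nM in this assay, at which 1 of the 4 values shown sits.

A plain phenyl at this carbon would show whether the aromatic ring alone accounts for the step or whether the two fluorines take part. An amine or a longer alkyl chain there would show whether groups without an aromatic ring do the same.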